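From naphthalen-1-yl to 4-methoxyphenyl on a sulfonyl sulfur

The source may report more compounds than this note shows. Statements on the series, on what has been measured and on what is new or still open speak of the compounds shown alone.

Compounds measured in a functional assay (plasma) for inhibition, with Oryctolagus cuniculus as the target; a lower number here means a stronger inhibitor, a higher number a weaker inhibitor:
Compound 1 `CCCCCCS(=O)(=O)N[C@H]1C2CC[C@H](C2)[C@@H]1C/C=C\CCCC(=O)O`: 13300 nM
Compound 2 `CN(C)c1ccc(S(=O)(=O)N[C@H]2C3CC[C@H](C3)[C@@H]2C/C=C\CCCC(=O)O)cc1`: 7100 nM
Compound 3 `O=C(O)CCC/C=C\C[C@H]1[C@@H]2CCC(C2)[C@@H]1NS(=O)(=O)c1cccc2ccccc12`: 1100 nM

Compound 3 has the lowest number of the three. Compound 4 `COc1ccc(S(=O)(=O)N[C@H]2C3CC[C@H](C3)[C@@H]2C/C=C\CCCC(=O)O)cc1`, not yet measured, carries 4-methoxyphenyl in place of naphthalen-1-yl on a sulfonyl sulfur. Among the measured groups, 4-(dimethylamino)phenyl in compound 2 is the closest to 4-methoxyphenyl. Its step of a 6.5-fold lower number from compound 2 to compound 3 (0.81 log units; beyond the scatter) is modest, and the step of a 1.9-fold lower number from compound 1 to compound 2 (0.27 log units; within the scatter) is within the scatter, while the step of a 12-fold lower number from compound 1 to compound 3 (1.08 log units; beyond the scatter) is large. A modest rise in this assay is therefore expected on losing naphthalen-1-yl. The expected step is a 4.5-fold higher number from compound 3 to compound 4 (0.66 log units; beyond the scatter). Compound 4 is estimated at 5000 nM, with an expected range from 1800 nM to 14000 nM.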

Compound 4, half-maximal inhibitory concentration: 1700 nM
The estimate for compound 4 lay 2.9-fold (0.47 log units) above the measured number; measured number outside the range, below it.
By their numbers in this assay, from the lowest: compounds 3 and 4 (each within the scatter of the next); then compounds 2 and 1 (each within the scatter of the next).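

In this assay, 4-methoxyphenyl in place of naphthalen-1-yl on a sulfonyl sulfur gives a 1.5-fold higher number from compound 3 to compound 4 (0.19 log units; within the scatter), so a group with one six-membered aromatic ring stays within the scatter of one with two. What the aromatic group carries also counts here: methoxy in place of dimethylamino on an aromatic carbon gives a 4.2-fold lower number from compound 2 to compound 4 (0.62 log units; beyond the scatter), and 4-methoxyphenyl in place of hexyl gives a 7.8-fold lower number from compound 1 to compound 4 (0.89 log units; beyond the scatter). Nothing available accounts for these steps. From the compounds shown here alone, whether plain phenyl, or a fluorine or hydroxyl in place of methoxy, would stay within that scatter remains open.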